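A few compounds are considered here, and "the series" means these few. Any claim that something is new, unique, unknown or untested is made for them only; others in the source may bear on it.

Working notes on the series in an assay on CHO cells for displacement of a labelled ligand from adenosine receptor A2b (Homo sapiens), read by scintillation counting, with a stated time of 75 min, in the presence of a further agent that is not named here; on this read-out lower numbers stand for stronger inhibition and higher numbers for weaker inhibition.

Compound 3 `CCCn1c(=O)[nH]c2nc(-c3ccc(S(=O)(=O)N4CCN(Cc5cccc(Br)c5)CC4)cc3)[nH]c2c1=O` gives 0.148 nM in this assay and stands at the lowest number of the three measured compounds. Compound 1 `CCCn1c(=O)[nH]c2nc(-c3ccc(S(=O)(=O)N4CCN(Cc5cccc(C)c5)CC4)cc3)[nH]c2c1=O` gives 0.397 nM, and compound 2 `CCCn1c(=O)[nH]c2nc(-c3ccc(S(=O)(=O)N4CCN(c5ccccc5C)CC4)cc3)[nH]c2c1=O` gives 0.432 nM. The step of a 2.7-fold lower number from compound 1 to compound 3 (0.43 log units; beyond the scatter) is modest but beyond the scatter, as is the step of a 2.9-fold lower number from compound 2 to compound 3 (0.47 log units; beyond the scatter). By contrast the step of a 1.1-fold higher number from compound 1 to compound 2 (0.04 log units; within the scatter) lies within the scatter.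

Compound 4 `CCCn1c(=O)[nH]c2nc(-c3ccc(S(=O)(=O)N4CCN(c5ccccc5Br)CC4)cc3)[nH]c2c1=O` is not yet measured. It differs from compound 3 by 2-bromophenyl in place of 3-bromobenzyl on an amine nitrogen in a ring. For the measured compounds named here, the change that bears most directly on it is the one from compound 1 to compound 2, where the same exchange of a benzyl for a phenyl on the ring nitrogen, carried out with methyl instead of bromo, gave a 1.1-fold higher number from compound 1 to compound 2 (0.04 log units; within the scatter), a step within the scatter. The bromo-for-methyl exchange itself, seen in a 2.7-fold lower number from compound 1 to compound 3 (0.43 log units; beyond the scatter), is already present in compound 3 and so does not enter again. Going by the values given here, no measured step combines bromo with a phenyl on the ring nitrogen, so the expectation rests on compounds 1 and 2 alone.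

On that basis the step from compound 3 to compound 4 is expected to be small, a 2.0-fold higher number from compound 3 to compound 4 (0.31 log units; beyond the scatter), with no change beyond the scatter anticipated. Compound 4 is therefore estimated at 0.3 nM in this assay, within a range of 0.1 nM to 0.9 nM.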

Compound 4, inhibition constant: 0.137 nM
Estimate against measurement, compound 4: 2.2-fold (0.34 log units) above, within the range that was stated.
By their numbers in this assay, from the lowest: compounds 4 and 3 (each within the scatter of the next); then compounds 1 and 2 (each within the scatter of the next).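

In this assay the exchange of 3-bromobenzyl for 2-bromophenyl on the amine nitrogen in a ring now reads with bromo as well as with methyl: the step of a 1.1-fold lower number from compound 3 to compound 4 (0.03 log units; within the scatter) stays within the scatter, as the methyl pair did, so neither pair tells the benzyl and phenyl forms apart. Bromo in place of methyl, so far seen only on the benzyl form, now also gives a 3.2-fold lower number from compound 2 to compound 4 (0.50 log units; beyond the scatter) on the phenyl form, and the step of a 2.9-fold lower number from compound 1 to compound 4 (0.46 log units; beyond the scatter), which changes both the attachment and the substituent, is likewise modest and beyond the scatter. Across these four compounds the lower numbers therefore go with bromo whichever attachment is present, and the two readings of that change agree: the same change on two cores in this assay, a 2.7-fold lower number (0.43 log units; beyond the scatter) from compound 1 to compound 3 and a 3.2-fold lower number (0.50 log units; beyond the scatter) from compound 2 to compound 4, 1.2-fold (0.07 log units) apart, within the scatter of two such steps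

Each attachment appears with its substituent in one placement only, so the effect of placement cannot be separated from the exchange of benzyl for phenyl. Only methyl and bromo are shown on the aromatic ring, which leaves open whether chloro, methoxy or a nitrile in the same place would read as bromo does.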